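This account rests on a few compounds, and the source may have more. Where it says the series, first, only, none or still open, it means among the compounds named here.

Compound 1 `Nc1ccn(C/C=C\CCl)c(=O)n1` carries a chloro group at the end of its chain and in a functional assay on L1210 cells (Mus musculus) for inhibition (on this read-out lower numbers stand for stronger inhibition and higher numbers for weaker inhibition), compound 1 gives 10000 nM. Compound 2 `Nc1ccn(C/C=C\CO)c(=O)n1` reaches only a limit of this assay, > 1000000 nM. The change between them, (hydroxy in place of chloro on a saturated chain carbon bound to a double-bonded chain carbon), brings an at least 100-fold higher number from compound 1 to compound 2 (2.00 log units; beyond the scatter); its true size is open because compound 2 sits at the limit of > 1000000 nM in this assay, at which 1 of the 3 values shown sits. Compound 3 `Nc1ncnc2c1ncn2CC#CCCl` has a different core, and how the two cores differ is not broken down here; in this assay compound 3 gives 90000 nM. Compound 4 `Nc1ncnc2c1ncn2CC#CCO` differs from compound 3 by hydroxy in place of chloro on a saturated chain carbon bound to a triple-bonded carbon, the same kind of change as before, though here the place is a saturated chain carbon bound to a triple-bonded carbon rather than to a double-bonded chain carbon. On the strength of an at least 100-fold higher number from compound 1 to compound 2 (2.00 log units; beyond the scatter), compound 4 is expected to weaken by a 33-fold higher number from compound 3 to compound 4 (1.52 log units; beyond the scatter), most likely beyond the limit. The estimate for compound 4 is 3000000 nM, between 400000 nM and 30000000 nM.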

Compound 4, half-maximal inhibitory concentration: 490000 nM
The estimate for compound 4 lay 6.1-fold (0.79 log units) above the measured number; the measured number falls inside the stated range.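

Swapping chloro for hydroxy again gives a weaker result in this assay, with a 5.4-fold higher number from compound 3 to compound 4 (0.74 log units; beyond the scatter) on the core of compound 3. The direction of the change carries over from one core to the other, but its size does not: the same change on two cores in this assay, an at least 100-fold higher number (2.00 log units; beyond the scatter) from compound 1 to compound 2 and a 5.4-fold higher number (0.74 log units; beyond the scatter) from compound 3 to compound 4, at least 18-fold (1.26 log units) apart, beyond the scatter of two such steps. Compound 2 gives > 1000000 nM, which is a limit and not a number, and the two pairs differ in the bond within the chain as well as in the core, leaving it unclear which of these sets the size.

Still open, from the compounds shown here alone, is how other groups in place of chloro, such as an amine or a methoxy group, would read on either core. A longer chain is also untested among the compounds shown here.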